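Replacing Isopropylcarbonyl with Methyl on a Sulfur

This account rests on a few compounds, and the source may have more. Where it says the series, first, only, none or still open, it means among the compounds named here.

This account follows a small set of compounds tested in an ADME assay on HEK293 cells (Homo sapiens) for inhibition, read by MTT assay, with a stated time of 96 h; a lower number here means a stronger inhibitor of growth, a higher number a weaker inhibitor of growth. Compound 1 `O=C(NCCCCCCSSCCCCCCNC(=O)c1cc(-c2ccncc2)n[nH]1)c1cc(-c2ccncc2)n[nH]1` gives 14800 nM, and compound 3 `C=CCOC(=O)SCCCCCCNC(=O)c1cc(-c2ccncc2)n[nH]1` gives 27500 nM. Compound 2 `CC(C)C(=O)SCCCCCCNC(=O)c1cc(-c2ccncc2)n[nH]1` gives > 50000 nM, which is a limit of the assay and not a number. Going by the values given here, it is the one compound of the three standing at the limit of > 50000 nM in this assay, at which 1 of the 3 values shown sits, so its true position is not known.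

The next compound to be measured is compound 4 `CSCCCCCCNC(=O)c1cc(-c2ccncc2)n[nH]1`. It carries methyl in place of isopropylcarbonyl on a sulfur, and that sulfur's other neighbour is a saturated chain carbon.

Among the compounds with values here, only one measured step starts from compound 2: an at least 1.8-fold lower number from compound 2 to compound 3 (0.25 log units; that floor lies within the scatter). It places allyloxy in place of isopropyl on a carbonyl carbon, and its floor stays within the scatter. Within the data shown here, that step keeps the carbonyl, whereas the change to compound 4 removes it, so no measured step covers this change directly. With so little to go on, no clear move away from the limit is expected. The expected change is a number no higher from compound 2 to compound 4 (the limit leaves the size open), an estimate that carries wide uncertainty. For compound 4 the estimated value is 50000 nM, within an expected range of 25000 nM to 100000 nM.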

Compound 4, concentration for 50% growth inhibition: > 50000 nM
Compound 4: only a limit was reported; the forecaster's own chance of this, stated with the estimate: 60%; the middle value sits exactly at the limit.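

In this assay the reading for compound 4 is > 50000 nM, which is a limit of the assay and not a number. With methyl in place of isopropylcarbonyl on this sulfur, the sulfur no longer carries a carbonyl, yet the result is a second limit, and the step between compound 2 and compound 4 cannot be read because both ends are limits: the limit of > 50000 nM in this assay, at which 2 of the 4 values shown sit.

Set against allyloxycarbonyl on the same sulfur, methyl gives an at least 1.8-fold higher number from compound 3 to compound 4 (0.25 log units; that floor lies within the scatter), so even the one readable step does not separate the two compounds.

The compounds shown leave open where the true values of compound 2 and compound 4 lie, and so whether swapping isopropylcarbonyl for methyl on this sulfur changes growth inhibition at all. They also leave open how a free thiol or an acetyl group on this sulfur would read in this assay, with the rest of the structure of compound 4 unchanged.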